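The source may report more compounds than this note shows. Statements on the series, on what has been measured and on what is new or still open speak of the compounds shown alone.

Within the data shown here, compound 2, `CC(C)C(Nc1nnc[nH]1)c1ccc(-c2ccc3cccc(F)c3c2)[nH]c1=O`, is one of two compounds measured so far in an ADME assay on microsomes from liver (Mus musculus) for metabolic stability; on this read-out higher numbers stand for a longer-lived compound and lower numbers for a shorter-lived compound. In this assay, among the measured compounds shown here, compound 2 gives 2.42 h, the only plain number among the two results. Compound 1, `CC(C)C(Cc1ncc[nH]1)c1ccc(-c2ccc3cccc(F)c3c2)[nH]c1=O`, differs from compound 2 in one place. In this assay compound 1 reaches only a limit of the assay, < 0.0667 h. For the measured compounds named here, the single measured step, an at least 36-fold higher number from compound 1 to compound 2 (1.55 log units; beyond the scatter), is large. Compound 3, `Cc1c[nH]c(C(c2ccc(-c3ccc4cccc(F)c4c3)[nH]c2=O)C(C)C)n1`, has not yet been measured. It differs from compound 2 by 4-methyl-1H-imidazol-2-yl in place of (4H-1,2,4-triazol-3-yl)amino on a saturated chain carbon bound to an aromatic carbon and a saturated chain carbon. This change runs in the opposite sense to the measured step: it removes the (4H-1,2,4-triazol-3-yl)amino group that the large step brought in and restores an imidazole ring, now as 4-methyl-1H-imidazol-2-yl, on a saturated chain carbon bound to an aromatic carbon and a saturated chain carbon. A large fall is therefore expected, an 8.1-fold lower number from compound 2 to compound 3 (0.91 log units; beyond the scatter), in this assay. Compound 3 is estimated at 0.3 h, with a range from 0.05 h to 1.2 h.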

Compound 3, half-life in the Mus musculus assay: < 0.0667 h
Compound 3: only a limit was reported; the forecaster's own chance of this, stated with the estimate: 25%; middle value at least 4.4-fold (0.65 log units) from the limit.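

At this saturated chain carbon, the Mus musculus assay now gives an at least 36-fold lower number from compound 2 to compound 3 (1.55 log units; beyond the scatter), so (4H-1,2,4-triazol-3-yl)amino remains the only group shown with a plain half-life, while a second imidazole-bearing group joins the (1H-imidazol-2-yl)methyl of compound 1 at the low end. Compound 1 and compound 3 each give only a limit of the assay, so the step between them cannot be read. In a physicochemical assay for solubility, measured as kinetic solubility, at pH 2 (a higher number here means a more soluble compound, a lower number a less soluble compound), compound 2 gives 39000 nM and compound 3 gives 6300 nM, a gap beyond the scatter, so compound 2 stands higher on both read-outs.

The compounds shown do not separate the part played by the triazole ring from that of the amino link. On these data alone, how a plain amine or a carboxylic acid at this carbon would behave on either read-out also remains open.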